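The source may report more compounds than this note shows. Statements on the series, on what has been measured and on what is new or still open speak of the compounds shown alone.

For the measured compounds named here, in a functional assay for inhibition, with Mus musculus as the target (a lower number here means a stronger inhibitor, a higher number a weaker inhibitor), compound 1 (`O=C(Nc1c(F)cc(F)cc1F)N(Cc1cccc(-c2cc[nH]n2)c1)C1CCCCCC1`) gives 580 nM, the lower of the two numbers so far, and compound 2 (`O=C(Nc1c(F)cc(F)cc1F)N(Cc1ccccc1)Cc1cccc(-c2cc[nH]n2)c1`) gives 7400 nM. Compound 3 (`Cc1cc(C)c(NC(=O)N(Cc2cccc(-c3cc[nH]n3)c2)C2CCCCCC2)c(C)c1`) keeps the cycloheptyl of compound 1 and changes one group: 2,4,6-trimethylphenyl in place of 2,4,6-trifluorophenyl on an amide-type nitrogen. That is 2,4,6-trimethylphenyl in place of 2,4,6-trifluorophenyl on an amide-type nitrogen. Going by the values given here, the only measured step, a 13-fold higher number from compound 1 to compound 2 (1.11 log units; beyond the scatter), is large, but it concerns benzyl in place of cycloheptyl and not this group. Among the compounds with values here, no measured pair varies the group now being changed, so the direction remains open. The measured step serves only as a rough scale, and a smaller move in this assay is expected, tilted slightly towards a higher number. The expected step is a 1.6-fold higher number from compound 1 to compound 3 (0.19 log units; within the scatter). For compound 3 the estimated value is 900 nM, with an expected range of 250 nM to 3000 nM.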

Compound 3, half-maximal inhibitory concentration: 460 nM
Estimate against measurement, compound 3: 2.0-fold (0.29 log units) above; the range from low to high includes it.
By their numbers in this assay, from the lowest: compounds 3 and 1 (each within the scatter of the next); then compound 2.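

In this assay, for the compounds shown here, the first measured pair at this place, on the amide-type nitrogen, gives a 1.3-fold lower number from compound 1 to compound 3 (0.10 log units; within the scatter) for 2,4,6-trimethylphenyl in place of 2,4,6-trifluorophenyl. With the cycloheptyl kept, the two aryl groups therefore cannot be told apart in this read-out, whereas the change of cycloheptyl to benzyl gave a 13-fold higher number from compound 1 to compound 2 (1.11 log units; beyond the scatter). No measurement at hand bears on why these two aryl groups read alike.

Going by these compounds, whether the two aryl groups also read alike with the benzyl of compound 2 in place of the cycloheptyl remains open. Also open, on these data alone, is how far this match extends beyond these two groups, for instance to an unsubstituted phenyl, a pyridine ring or a phenyl carrying a carboxylic acid.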